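Hydroxy to Dimethylamino: Expected Cytotoxicity of Compound 3

The source may report more compounds than this note shows. Statements on the series, on what has been measured and on what is new or still open speak of the compounds shown alone.

Compound 1, `CC1=CC[C@@H]([C@@](C)(O)CCCC(C)(C)NC(=S)N/N=C\c2ccc(C)cc2)CC1`, gives in a functional assay on HT-29 cells (Homo sapiens) for cytotoxicity, read by sulforhodamine B assay (on this read-out higher numbers stand for lower toxicity in this test and lower numbers for higher toxicity in this test), only a limit, > 100000 nM.
Compound 2, `CC1=CC[C@@H]([C@@](C)(O)CCCC(C)(C)NC(=S)N/N=C\c2ccc(O)cc2)CC1`, gives in this assay 58500 nM.

Within the data shown here, compound 2 thus holds the only true number in this assay; the other value is a limit. Compound 3, `CC1=CC[C@@H]([C@@](C)(O)CCCC(C)(C)NC(=S)N/N=C\c2ccc(N(C)C)cc2)CC1`, is not yet measured and differs from compound 2 by dimethylamino in place of hydroxy on an aromatic carbon. Among the measured compounds shown here, the single measured step, an at least 1.7-fold lower number from compound 1 to compound 2 (0.23 log units; that floor lies within the scatter), starts from a limit of > 100000 nM in this assay, at which 1 of the 2 values shown sits, and concerns methyl to hydroxy, a different change, so no measured step bears directly on the present one. No shift beyond the scatter is therefore expected in this assay. Compound 3 is estimated at 60000 nM, between 25000 nM and 150000 nM. The expected step from compound 2 is a 1.0-fold higher number from compound 2 to compound 3 (0.01 log units; within the scatter), within the scatter.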

Compound 3, concentration lethal to 50% of the cells: > 100000 nM
Compound 3: a limit, no number; the forecaster's own chance of this, stated with the estimate: 35%; middle value at least 1.6-fold (0.22 log units) away from the limit.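

At this position on the aromatic ring, hydroxy is now the only one of the three groups shown that gives a true number in this assay. Dimethylamino in place of hydroxy gives an at least 1.7-fold higher number from compound 2 to compound 3 (0.23 log units; that floor lies within the scatter), so this change cannot be called a real shift on these values. The step between compound 1 and compound 3 cannot be read, since both stop at a limit: the limit of > 100000 nM in this assay, at which 2 of the 3 values shown sit.

From the compounds shown here alone, how far the true values of compound 1 and compound 3 lie from that of compound 2 stays open. So does what a primary amine or a carboxylic acid at this position would give in this assay.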